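Hydroxy for amino: an expectation for compound 4

The compounds below may be only part of what the source reports. "The series", "measured", "known", "first", "only" and "open" are said of these compounds alone.

Three compounds have so far been measured in a functional assay on SMMC-7721 cells (Homo sapiens) for inhibition, read by MTT assay, with a stated time of 72 h; on this read-out lower numbers stand for stronger inhibition and higher numbers for weaker inhibition:
compound 1, `COc1cc(-c2c(-c3ccc4cc[nH]c4c3)c(=O)c2=O)cc(OC)c1OC`, gives 2540 nM
compound 2, `COc1cc(-c2c(-c3ccc4[nH]ccc4c3)c(=O)c2=O)cc(OC)c1OC`, gives 646 nM
compound 3, `COc1ccc(-c2c(-c3cc(OC)c(OC)c(OC)c3)c(=O)c2=O)cc1N`, gives 190 nM

On these numbers compound 3 stands lowest of the three. The steps that lead to it are a 13-fold lower number from compound 1 to compound 3 (1.13 log units; beyond the scatter) and a 3.4-fold lower number from compound 2 to compound 3 (0.53 log units; beyond the scatter), and between the first two compounds there is a 3.9-fold lower number from compound 1 to compound 2 (0.59 log units; beyond the scatter). Compound 4, `COc1ccc(-c2c(-c3cc(OC)c(OC)c(OC)c3)c(=O)c2=O)cc1O`, differs from compound 3 in one place: hydroxy in place of amino on an aromatic carbon. Within the data shown here, none of the measured steps touches this change. Each of them swaps the whole group that sits on the shared core for another, whereas here that group is kept and only one substituent on it is exchanged, one heavy atom for one heavy atom. There is thus no measured basis for predicting a step in either direction, and compound 4 is expected to land close to compound 3, with a 1.3-fold lower number from compound 3 to compound 4 (0.10 log units; within the scatter) falling within the usual scatter. The estimate for compound 4 in this assay is 150 nM, with a range from 40 nM to 600 nM.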

Compound 4, half-maximal inhibitory concentration: 1520 nM
Beside the measured number, compound 4's estimate is 10-fold (1.01 log units) below it; the measured number lies above the stated range.
By their numbers in this assay, from the lowest: compound 3; then compound 2; then compounds 4 and 1 (each within the scatter of the next).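

In this assay, the position on the six-membered aromatic ring, ortho to a methoxy group, proves sensitive to a single-atom exchange: hydroxy in place of amino gives an 8.0-fold higher number from compound 3 to compound 4 (0.90 log units; beyond the scatter) even though the rest of the molecule is unchanged and the two groups have the same counts of heavy atoms, hydrogen-bond donors and hydrogen-bond acceptors. The exchange also removes the advantage of the 3-amino-4-methoxyphenyl group over the indolyl groups, with a 2.4-fold higher number from compound 2 to compound 4 (0.37 log units; beyond the scatter) on one side, while a 1.7-fold lower number from compound 1 to compound 4 (0.22 log units; within the scatter) leaves the 3-hydroxy-4-methoxyphenyl and 1H-indol-6-yl compounds indistinguishable on the other. Nothing available accounts for the difference between amino and hydroxy at this position.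

The compounds shown leave open whether the low number depends on the free amino group itself or would persist with a methylamino, dimethylamino or acetamido group, or with a fluorine atom, at the same place. They also leave open whether hydroxy and amino would differ in the same way if the methoxy group were replaced by an ethoxy group or a chlorine atom.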